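Cytotoxicity limits and a (pyridin-3-yl)methoxy replacement

The source may report more compounds than this note shows. Statements on the series, on what has been measured and on what is new or still open speak of the compounds shown alone.

Of the compounds shown here, two on the shared core have been tested in an ADME assay on HEK293 cells (Homo sapiens) for cytotoxicity, with a stated time of 6 h; a lower number here means that less compound is tolerated, a higher number that more compound is tolerated: compound 1 (`CCCCNc1nc(N)nc2ccc(F)cc12`) and compound 2 (`CCCCNc1nc(N)nc2cccc(CC3CCCC3)c12`). Compound 1 gives > 18000 nM, which is a limit. Compound 2 gives > 25000 nM, likewise a limit. Compound 3 (`CCCCNc1nc(N)nc2cccc(OCc3cccnc3)c12`) carries (pyridin-3-yl)methoxy in place of cyclopentylmethyl on an aromatic carbon. For the measured compounds named here, no measured step is available to size the change. The expected step of a number no higher from compound 2 to compound 3 (the limit leaves the size open) in this assay is none beyond the scatter. For compound 3 the estimated value is 25000 nM, with an expected range of 10000 nM to 60000 nM.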

Compound 3, half-maximal cytotoxic concentration: > 25000 nM
Compound 3 was reported as a limit (the forecaster's own chance of this, stated with the estimate: 70%); the middle value lies on the limit itself.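

No step from compound 2 to compound 3 can be read in this assay, because both are reported only as limits: the limit of > 25000 nM in this assay, at which 2 of the 3 values shown sit.

The compounds shown leave open where the half-maximal cytotoxic concentrations of compound 1, compound 2 and compound 3 actually lie.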